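This account rests on a few compounds, and the source may have more. Where it says the series, first, only, none or still open, it means among the compounds named here.

Measured compounds:
compound 1, `COc1ccc(-c2cc3ccccc3c(-c3cccc(OC)c3)n2)cc1`: in a functional assay on DU-145 cells (Homo sapiens) for cytotoxicity, read by CCK-8 assay and cell counting, with a stated time of 72 h (a higher number here means a weaker inhibitor, a lower number a stronger inhibitor), compound 1 gives > 50000 nM
compound 2, `COc1cc(OC)cc(-c2cc3ccccc3c(-c3cccc(O)c3)n2)c1`: compound 2 gives 3870 nM

The value for compound 1 is a limit of the assay, not a number. Within the data shown here, compound 2 therefore stands as the only measured number here, and the sole point of reference. Compound 3, `COc1cc(OC)cc(-c2cc3ccccc3c(-c3cccc(OC)c3)n2)c1`, has yet to be measured in this assay. Compound 3 differs from compound 2 by methyl in place of hydrogen on an oxygen on an aromatic ring, so that the hydroxy group becomes a methoxy group. Among the measured compounds shown here, no measured pair shows this single change on its own. Compound 1 carries a methoxy on each outer ring and reaches only a limit. Compound 2, which carries a free hydroxy, gives a number; since these two compounds differ in more than one place, their values show only that much. On that basis the step is expected to be a 5.2-fold higher number from compound 2 to compound 3 (0.71 log units; beyond the scatter), a weakening beyond the usual scatter. For compound 3 the expected value is 20000 nM, likely between 6000 nM and 50000 nM, with a real possibility that only a limit is reported.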

Compound 3, half-maximal inhibitory concentration: > 50000 nM
Compound 3: a limit, no number; the forecaster's own chance of this, stated with the estimate: 40%; at least 2.5-fold (0.39 log units) between middle value and limit.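

In this assay, among these compounds, this is the first pair that differs in one place, and it gives an at least 12-fold higher number from compound 2 to compound 3 (1.11 log units; beyond the scatter) when 3-hydroxyphenyl becomes 3-methoxyphenyl. Among the compounds shown here, compound 1 had already hinted at this, but it differs from compound 2 in more than one place, so the hydroxy group could not be singled out; here, a single methyl on that oxygen is the only change, and it is enough to separate a measured number from no number at all. On these data alone, the true size of the step remains unknown, and the figure is only a lower bound, because compound 3 reads as a limit of the assay and not as a number: the limit of > 50000 nM in this assay, at which 2 of the 3 values shown sit.

What these compounds leave open is whether the hydrogen on that oxygen is what counts, or whether another group in the same place, such as an amine or a carboxylic acid, would also give a measurable number. For the compounds shown here, they also do not show how much the two methoxy groups on the other outer ring of compound 2 contribute, as no pair here changes those groups alone.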